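The source may report more compounds than this note shows. Statements on the series, on what has been measured and on what is new or still open speak of the compounds shown alone.

Of the compounds shown here, two have been tested so far in a functional assay on the whole organism for agonist activity, with Mus musculus as the target; on this read-out lower numbers stand for an effect already at smaller amounts and higher numbers for an effect only at larger amounts of compound. Compound 1 `CC1CCC(=O)N1CC#CCn1ccnc1` gives > 100 mg/kg, and this is a limit of the assay rather than a number. Going by the values given here, compound 2 `O=C1NCCN1CC#CCn1ccnc1` gives 17.3 mg/kg in this assay, which makes it the only compound with a true number, and so the one real reference point. The two structures differ in more than one place, so the effect of any single change cannot be read from this pair.

Compound 3 `Cc1cncn1CC#CCN1CCNC1=O` is built directly on compound 2. The change is methyl in place of hydrogen on an aromatic carbon, next to the ring nitrogen and next to the ring atom that bears a large group. Among the compounds with values here, no measured pair shows what such a change does in this assay, so the expectation rests on compound 2 at 17.3 mg/kg and is held loosely. The estimated step is a 1.7-fold higher number from compound 2 to compound 3 (0.24 log units; within the scatter), a small expected move toward larger doses that stays within the usual scatter. For compound 3 the expected value is 30 mg/kg, with an estimated range from 8 mg/kg to 100 mg/kg.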

Compound 3, dose for half-maximal effect: > 100 mg/kg
Compound 3 gave a limit, no number; the forecaster's own chance of this, stated with the estimate: 20%; middle value at least 3.3-fold (0.52 log units) away from the limit.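

Methyl in place of hydrogen on an aromatic carbon, next to the ring nitrogen and next to the ring atom that bears a large group, is the first change here that can be read on its own, and in this assay it gives an at least 5.7-fold higher number from compound 2 to compound 3 (0.76 log units; beyond the scatter). From the compounds shown here alone, the value of compound 3 is a limit and not a number, so this step fixes only a smallest size, and its full size stays unknown. Going by these compounds alone, this position of the five-membered aromatic ring therefore does not accept even one added carbon without a clear loss on this read-out, as a single methyl takes the series from its only true number back to a limit: the limit of > 100 mg/kg in this assay, at which 2 of the 3 values shown sit.

The compounds shown leave open whether this loss belongs to methyl alone or to any group at this position, since no smaller atom such as fluorine and no longer chain such as ethyl stands there. They also leave open whether methyl on another carbon of the same ring would give the same result, and compound 1 cannot settle this, as it differs from the others in more than one place.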